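The source may report more compounds than this note shows. Statements on the series, on what has been measured and on what is new or still open speak of the compounds shown alone.

Three compounds share one core and differ only in the group at the end of a short chain. Compound 1 `N=C(S)CCCn1nc(-c2ccccc2)ccc1=O` in a functional assay on the whole organism (stomach) for inhibition, with Rattus norvegicus as the target, at a dose of 100 mg/kg by the intraduodenal route (a higher number here means more inhibition at the dose given (going by the name of the read-out), a lower number less inhibition), gives 75.6%. Compound 2 `N#CCCn1nc(-c2ccccc2)ccc1=O` gives 10.1%, and compound 3 `NC(=O)CCn1nc(-c2ccccc2)ccc1=O` gives -2.8%, the lowest of the three numbers, with a number 78.4 percentage points lower from compound 1 to compound 3 (beyond the scatter) and a number 12.9 percentage points lower from compound 2 to compound 3 (beyond the scatter). Compound 4 `CCOC(=O)CCn1nc(-c2ccccc2)ccc1=O` differs from compound 3 by ethoxy in place of amino on a carbonyl carbon. Within the data shown here, no measured step changes an amino group on a carbonyl carbon. The nearest comparison is a number 12.9 percentage points lower from compound 2 to compound 3 (beyond the scatter), a modest change, whereas a number 65.5 percentage points lower from compound 1 to compound 2 (beyond the scatter) and a number 78.4 percentage points lower from compound 1 to compound 3 (beyond the scatter) show that the chain end can shift the read-out greatly. The expected step for compound 4 is small, a number 12.8 percentage points higher from compound 3 to compound 4 (beyond the scatter). Compound 4 is therefore estimated at 10%, within a range from -10% to 35%.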

Compound 4, a percentage reported as inhibition, in the whole organism at one dose (the size of the read-out at that dose, not a potency): 6.3%
Beside the measured number, compound 4's estimate is 3.7 percentage points above it, and the stated range covers the measured number.
By their numbers in this assay, from the lowest: compounds 3, 4 and 2 (each within the scatter of the next, the first and the last beyond it); then compound 1.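

In this assay, ethoxy in place of amino on the carbonyl carbon gives a number 9.1 percentage points higher from compound 3 to compound 4 (within the scatter), so at this chain end the two groups cannot be told apart. Ethoxycarbonyl and cyano also cannot be told apart, with a number 3.8 percentage points lower from compound 2 to compound 4 (within the scatter), and the large gap in a number 69.3 percentage points lower from compound 1 to compound 4 (beyond the scatter) shows that compound 1 alone stays high among these four compounds. Going by these compounds, whether a carboxylic acid at the chain end, or ethoxycarbonyl on a longer chain, would come closer to compound 1 remains open. No measurement here gives a reason for these numbers.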